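The source may report more compounds than this note shows. Statements on the series, on what has been measured and on what is new or still open speak of the compounds shown alone.

In a functional assay on MCF7 cells (Homo sapiens) for antiproliferative activity, read by MTT assay, with a stated time of 72 h (on this read-out lower numbers stand for stronger inhibition and higher numbers for weaker inhibition), compound 1 `CN(c1ccccc1Cl)S(=O)(=O)C1CC2OC1C(c1ccc(NC(=O)CCCCCCC(=O)O)cc1)=C2c1ccc(O)cc1` gives 12800 nM and compound 2 `CN(c1ccc(Cl)cc1)S(=O)(=O)C1CC2OC1C(c1ccc(NC(=O)CCCCCCC(=O)O)cc1)=C2c1ccc(O)cc1` gives 13700 nM and so stands level with compound 1 within the scatter. Compound 3 `CCN(c1ccc(C)cc1)S(=O)(=O)C1CC2OC1C(c1ccc(NC(=O)CCCCCCC(=O)O)cc1)=C2c1ccc(O)cc1` carries ethyl(4-methylphenyl)amino in place of (4-chlorophenyl)(methyl)amino on a sulfonyl sulfur and has not yet been measured. Going by the values given here, the only measured step that bears on this change is a 1.1-fold higher number from compound 1 to compound 2 (0.03 log units; within the scatter) and it concerns the chlorophenyl group on a sulfonamide nitrogen. Among the compounds with values here, it stayed within the scatter, but it is only a partial guide, since no measured compound varies the alkyl group or replaces the chlorine. No step beyond the scatter is therefore expected in this assay on this evidence. The expected move is a 1.1-fold lower number from compound 2 to compound 3 (0.02 log units; within the scatter) and it is estimated to stay within the scatter. For compound 3 the estimate is 13000 nM with an expected range from 6500 nM to 26000 nM in this assay.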

Compound 3, half-maximal inhibitory concentration: 42300 nM
Estimate against measurement, compound 3: 3.3-fold (0.51 log units) below; the whole stated range lies below it.
By their numbers in this assay, from the lowest: compounds 1 and 2 (each within the scatter of the next); then compound 3.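

In this assay, ethyl(4-methylphenyl)amino in place of (4-chlorophenyl)(methyl)amino on a sulfonyl sulfur gives a 3.1-fold higher number from compound 2 to compound 3 (0.49 log units; beyond the scatter), and in place of (2-chlorophenyl)(methyl)amino it gives a 3.3-fold higher number from compound 1 to compound 3 (0.52 log units; beyond the scatter). This shows for the first time that a change in the group on the sulfonyl sulfur can move the number beyond the scatter, here towards weaker inhibition, which the exchange of 2-chlorophenyl for 4-chlorophenyl had not shown. Nothing available explains this loss.

The change alters the alkyl group and the ring substituent together, so the compounds shown do not separate their contributions to the step. Going by these compounds alone, that question stays open for (4-chlorophenyl)(ethyl)amino and methyl(4-methylphenyl)amino, each of which carries only one of the two changes.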